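Notes on the substituent at the aromatic nitrogen

A few compounds are considered here, and "the series" means these few. Any claim that something is new, unique, unknown or untested is made for them only; others in the source may bear on it.

Values in an assay on 32D cells for inhibition of interleukin-15 (Mus musculus), read by resazurin assay, with stated times of 30 min and 2.5 days, in the presence of a further agent that is not named here; on this read-out higher numbers stand for weaker inhibition and lower numbers for stronger inhibition:
compound 1 `Cn1c(Cc2nn(C)c(=O)c3ccccc23)nnc1SCCCCCCCC(=O)Nc1ccc(Cl)cc1Cl`: 3900 nM
compound 2 `Cn1nc(Cc2nnc(SCCCCCCCC(=O)Nc3ccc(Cl)cc3Cl)[nH]2)c2ccccc2c1=O`: 3500 nM
compound 3 `Cn1nc(Cc2nnc(SCCCCCCCC(=O)Nc3ccc(Cl)cc3Cl)n2CCCO[Si](C)(C)C(C)(C)C)c2ccccc2c1=O`: > 30000 nM, a limit of the assay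

Among the compounds with values here, compound 3 stands at the limit of this assay; its > 30000 nM is a limit and not a number, the one value sitting at the limit of > 30000 nM in this assay, at which 1 of the 3 values shown sits. Compound 1 and compound 2 both give numbers, and a 1.1-fold lower number from compound 1 to compound 2 (0.05 log units; within the scatter) is within the scatter. The change to compound 4 `CN(C)CCCn1c(Cc2nn(C)c(=O)c3ccccc23)nnc1SCCCCCCCC(=O)Nc1ccc(Cl)cc1Cl` is a group of 3 heavy atoms (2 carbon, 1 nitrogen; no ring) in place of a group of 8 heavy atoms (6 carbon, 1 oxygen, 1 silicon; no ring), on a saturated chain carbon, three bonds along the chain from an aromatic nitrogen. Within the data shown here, the steps that bear on it are an at least 7.6-fold higher number from compound 1 to compound 3 (0.88 log units; beyond the scatter) and an at least 8.5-fold higher number from compound 2 to compound 3 (0.93 log units; beyond the scatter); both went from a small substituent on the aromatic nitrogen to the long silyl-bearing chain, and both crossed the scatter. Compound 4 keeps a three-carbon chain on that nitrogen but loses the larger part of what was added, so part of that loss is expected to be recovered, without a firm anchor for how much. For compound 4 the expectation in this assay is 10000 nM, between 3000 nM and 40000 nM. The expected step of an at least 3.0-fold lower number from compound 3 to compound 4 (0.47 log units; beyond the scatter) is a move to stronger inhibition, with a real chance that only a limit is reported again.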

Compound 4, half-maximal inhibitory concentration: 5500 nM
The estimate for compound 4 lay 1.8-fold (0.26 log units) above the measured number; low and high end bracket the measured number.
By their numbers in this assay, from the lowest: compounds 2, 1 and 4 (each within the scatter of the next). At a limit, above all of these: compound 3.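

With dimethylamino in place of the silyl-bearing end of the chain, the series returns to a measurable number (an at least 5.4-fold lower number from compound 3 to compound 4 (0.73 log units; beyond the scatter)), so a propyl chain on the aromatic nitrogen does not by itself abolish the read-out. The 3-(dimethylamino)propyl group of compound 4 gives no separation from the smaller substituents (a 1.6-fold higher number from compound 2 to compound 4 (0.20 log units; within the scatter); a 1.4-fold higher number from compound 1 to compound 4 (0.15 log units; within the scatter)), which places this position as open to substitution within the compounds shown. Compound 3 remains a limit and not a number, so the full size of the recovery cannot be read: the limit of > 30000 nM in this assay, at which 1 of the 4 values shown sits.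

Going by these compounds, whether the end group matters among small groups stays open; a hydroxyl, a carboxylic acid or a morpholine at the end of the same propyl chain would test this. On these data alone, how much chain length this nitrogen accepts is also open, and a longer chain ending in dimethylamino would address it.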